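Replacing methylsulfonyl with fluoro in a weak antagonist pair

A few compounds are considered here, and "the series" means these few. Any claim that something is new, unique, unknown or untested is made for them only; others in the source may bear on it.

Measured compounds:
compound 1, `Cc1cc(COc2ccc(C#N)cc2)nc(-c2ccccn2)n1`, 31600 nM
compound 2, `Cc1cc(COc2ccc(S(C)(=O)=O)cc2)nc(-c2ccccn2)n1`, a limit of > 39800 nM

In a functional assay on cells for antagonist activity at Free fatty acid receptor 1 (Homo sapiens), read by TR-FRET and inositol phosphate accumulation, with a stated time of 2 h (a higher number here means a weaker inhibitor, a lower number a stronger inhibitor), compound 1 gives 31600 nM. Compound 2 reaches only the assay limit, > 39800 nM, and so sits at the limit of > 39800 nM in this assay, at which 1 of the 2 values shown sits, with no number of its own. Going by the values given here, the single measured step, an at least 1.2-fold higher number from compound 1 to compound 2 (0.10 log units; that floor lies within the scatter), is the only guide, and it carries no direction beyond the scatter. Compound 3 `Cc1cc(COc2ccc(F)cc2)nc(-c2ccccn2)n1` arises from compound 2 by fluoro in place of methylsulfonyl on an aromatic carbon. No shift beyond the scatter is expected, and the estimated step is an at least 1.1-fold lower number from compound 2 to compound 3 (0.05 log units; that floor lies within the scatter). Compound 3 is therefore expected to give about 35000 nM, between 12000 nM and 100000 nM.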

Compound 3, half-maximal inhibitory concentration: 631 nM
The estimate for compound 3 lay 55-fold (1.74 log units) above the measured number, and the stated range ends above it.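

On this aromatic carbon, the group decides the activity far more strongly than the first pair could show, since that pair's step stayed within the scatter. Fluoro in place of nitrile brings a 50-fold lower number from compound 1 to compound 3 (1.70 log units; beyond the scatter), and fluoro in place of methylsulfonyl brings an at least 63-fold lower number from compound 2 to compound 3 (1.79 log units; beyond the scatter). The value of compound 2 is a limit and not a number: the limit of > 39800 nM in this assay, at which 1 of the 3 values shown sits.

From the compounds shown here alone, it remains open whether this gain is specific to fluoro or is shared by other small groups. Chloro, methyl or an amine on the same carbon would begin to separate these readings.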